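The source may report more compounds than this note shows. Statements on the series, on what has been measured and on what is new or still open speak of the compounds shown alone.

Of the compounds shown here, three built on one shared core have been tested in a functional assay on MRC5 cells (Homo sapiens); on this read-out higher numbers stand for lower toxicity in this test and lower numbers for higher toxicity in this test. Compound 1 `Cc1ccc(CN2c3ccccc3C(=O)N(Cc3ccccc3)S2(=O)=O)cc1` gives 63000 nM there. Compound 2 `O=C1c2ccccc2N(Cc2ccc(Cl)cc2)S(=O)(=O)N1Cc1ccc(Cl)cc1` gives 56000 nM, and compound 3 `O=C1c2ccccc2N(Cc2ccc(Cl)c(Cl)c2)S(=O)(=O)N1Cc1ccc(Cl)c(Cl)c1` gives 48000 nM. Compound 1 carries the largest of these three numbers, yet its gaps to compound 2 and to compound 3 both fall within the usual scatter, so the three stand together in this assay. Compound 4 `O=C1c2ccccc2N(Cc2ccccc2Cl)S(=O)(=O)N1Cc1ccccc1` has not yet been measured. It differs from compound 1 in one place: 2-chlorophenyl in place of 4-methylphenyl on a saturated chain carbon bound to a sulfonamide nitrogen in a ring. With compound 2 at 56000 nM and compound 3 at 48000 nM sitting alongside compound 1, no step beyond the scatter is expected in either direction. The step from compound 1 to compound 4 is expected to be a 1.1-fold lower number from compound 1 to compound 4 (0.06 log units; within the scatter). Compound 4 is estimated at 55000 nM, between 30000 nM and 100000 nM.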

Compound 4, half-maximal cytotoxic concentration: 60000 nM
For compound 4 the middle estimate is 1.1-fold (0.04 log units) below the measured one; low and high end bracket the measured number.
By their numbers in this assay, from the lowest: compounds 3, 2, 4 and 1 (each within the scatter of the next).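

The change to 2-chlorophenyl in place of 4-methylphenyl on a saturated chain carbon bound to a sulfonamide nitrogen in a ring gives a 1.1-fold lower number from compound 1 to compound 4 (0.02 log units; within the scatter) in this assay. This is the only step shown that isolates one place, and it shows that this exchange of one ring substituent and its location leaves the number within the scatter. No available evidence bears on this result. As far as these compounds go, whether an amine or a carboxylic acid on this phenyl ring, or a longer chain in place of the benzyl group, would shift the number remains open.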